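The source may hold more compounds than are shown below. What is called first, only, known or untested is meant among the compounds shown, and "the series" means these compounds.

Measured in a functional assay on CEM-DNR-bulk cells (Homo sapiens), read by MTT assay, with a stated time of 72 h; a higher number here means a weaker inhibitor, a lower number a stronger inhibitor:
- compound 1 `Nc1nc2c(c(-c3ccoc3)cn2[C@@H]2O[C@H](CO)[C@@H](O)[C@H]2O)c(=O)[nH]1`: 15000 nM
- compound 2 `Nc1nc2c(c(-c3ccccc3)cn2[C@@H]2O[C@H](CO)[C@@H](O)[C@H]2O)c(=O)[nH]1`: > 20000 nM, a limit of the assay and not an exact number

Compound 2 stands at the limit of this assay, and the exact figure for compound 2 is not known: the limit of > 20000 nM in this assay, at which 1 of the 2 values shown sits. Compound 3 `Nc1nc2c(c(-c3cc4ccccc4o3)cn2[C@@H]2O[C@H](CO)[C@@H](O)[C@H]2O)c(=O)[nH]1` keeps the shared core and changes one group, with 1-benzofuran-2-yl in place of phenyl on an aromatic carbon.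

Going by the values given here, only one measured step bears on this place, an at least 1.3-fold higher number from compound 1 to compound 2 (0.12 log units; that floor lies within the scatter), where phenyl replaced furan-3-yl. On these data alone, that step is small, and it gives only a floor, so the true gap remains unknown. It offers no reason to expect a large change in either direction. Compound 3 is therefore expected to stay weak in this assay, with no step beyond the scatter, and it may well return only a limit again.

The expected change is a number no higher from compound 2 to compound 3 (the limit leaves the size open). For compound 3 the estimated value is 20000 nM, with an expected range from 7000 nM to 40000 nM.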

Compound 3, half-maximal inhibitory concentration: > 20000 nM
Compound 3: only a limit was reported; the forecaster's own chance of this, stated with the estimate: 60%; the middle value lies on the limit itself.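

In this assay compound 3 gives > 20000 nM, which is a limit and not a number, and this puts a second group, the larger 1-benzofuran-2-yl with its two aromatic rings, at the same limit as phenyl: the limit of > 20000 nM in this assay, at which 2 of the 3 values shown sit.

The step between compound 2 and compound 3 cannot be read, since both values are limits, and so the data cannot tell whether this swap changed anything at all. Going by these compounds alone, the one readable comparison is an at least 1.3-fold higher number from compound 1 to compound 3 (0.12 log units; that floor lies within the scatter), which means that a second aromatic ring on this carbon gives no sign of a stronger inhibitor than the furan-3-yl compound.

The compounds shown leave open the exact numbers for compound 2 and compound 3, and therefore any ranking among the aromatic groups tried at this position. They also leave open whether a group of a different kind on the same carbon, such as a small methyl, an amine or a carboxylic acid, would bring the number in this assay clearly down.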